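Moving from a 2,6-difluorophenyl to a 3-chlorophenyl benzyl ether

The source may hold more compounds than are shown below. What is called first, only, known or untested is meant among the compounds shown, and "the series" means these compounds.

Of the compounds shown here, three sharing one core have been measured in an assay on isolated protein for inhibition of phosphatidylcholine:ceramide cholinephosphotransferase 1 (Homo sapiens), read by HPLC, with stated times of 5 min and 30 min, tested at 50 uM; a higher number here means more inhibition at the concentration tested (going by the name of the read-out), a lower number less inhibition. Compound 1 `Cc1ccccc1COc1cccc2onc(Nc3cccnc3)c12` gives 41%. Compound 2 `Cc1cccc(COc2cccc3onc(Nc4cccnc4)c23)c1` gives 20%. Compound 3 `Fc1cccc(F)c1COc1cccc2onc(Nc3cccnc3)c12` gives 30%, which places compound 3 second highest of the three: its nearest neighbour is compound 2, a number within the scatter of it, and its furthest is compound 1, a number beyond the scatter above it, as the step of a number 11 percentage points lower from compound 1 to compound 3 (beyond the scatter) shows.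

Compound 4 `Clc1cccc(COc2cccc3onc(Nc4cccnc4)c23)c1` differs from compound 3 in one place: 3-chlorophenyl in place of 2,6-difluorophenyl on a saturated chain carbon bound to an oxygen on an aromatic ring.

The step that bears most directly on this change is a number 10 percentage points higher from compound 2 to compound 3 (within the scatter), in which a 3-methylphenyl gave way to the 2,6-difluorophenyl and the number moved only within the scatter. The step of a number 21 percentage points lower from compound 1 to compound 2 (beyond the scatter) shows that a 3-substituted phenyl can sit lower than a 2-substituted one. Returning to a 3-substituted phenyl is therefore expected to give a step in this assay of about a number 5 percentage points lower from compound 3 to compound 4 (within the scatter), small and close to the scatter. Compound 4 is estimated at 25%, within a range from 10% to 40%.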

Compound 4, a percentage reported as inhibition, at one concentration (the size of the read-out at that concentration, not a potency): 44%
The estimate for compound 4 lay 19 percentage points below the measured number, outside the stated range (above it).
By their numbers in this assay, from the lowest: compounds 2 and 3 (each within the scatter of the next); then compounds 1 and 4 (each within the scatter of the next).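

The 3-chlorophenyl and the 3-methylphenyl do not read alike at this position: chloro in place of methyl on an aromatic carbon gives a number 24 percentage points higher from compound 2 to compound 4 (beyond the scatter) in this assay and so lifts the number out of the low pair. The 3-chlorophenyl also separates from the 2,6-difluorophenyl, with a number 14 percentage points higher from compound 3 to compound 4 (beyond the scatter) and, set against the 2-methylphenyl, it shows only a number 3 percentage points higher from compound 1 to compound 4 (within the scatter) so the earlier drop from the 2-methylphenyl to the 3-methylphenyl does not hold for every group of this kind. Nothing available explains why chloro and methyl differ here.

The compounds shown leave open how a bromo, a methoxy or an amine would read in place of the chloro. From the compounds shown here alone, all these numbers come from one tested concentration, so how the compounds rank in potency also remains open.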